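From pyridin-2-yl to oxan-4-yl on the shared core

A few compounds are considered here, and "the series" means these few. Any claim that something is new, unique, unknown or untested is made for them only; others in the source may bear on it.

Measured in a physicochemical assay for lipophilicity, at pH 7.4 (a higher number here means a more lipophilic compound, a lower number a more polar compound), so far
Compound 1 `CNC(=O)c1cc(C(=O)N[C@H]2[C@@H]3COC[C@@H]32)cc2c1OC[C@H]2c1ccccc1` gives 3.3
Compound 2 `CNC(=O)c1cc(C(=O)N[C@H]2[C@@H]3COC[C@@H]32)cc2c1OC[C@H]2c1ccncc1` gives 1.3
Compound 3 `CNC(=O)c1cc(C(=O)N[C@H]2[C@@H]3COC[C@@H]32)cc2c1OC[C@H]2c1ccccn1` gives 1.6

Two steps place compound 3 in this assay, a large one (a number 1.70 log units lower from compound 1 to compound 3 (beyond the scatter)) and one that stays small (a number 0.30 log units higher from compound 2 to compound 3 (within the scatter)). Compound 4 `CNC(=O)c1cc(C(=O)N[C@H]2[C@@H]3COC[C@@H]32)cc2c1OC[C@H]2C1CCOCC1` carries oxan-4-yl in place of pyridin-2-yl on a saturated ring carbon. Among the compounds with values here, no measured step brings in oxan-4-yl. The nearest guides are the large replacements of phenyl (a number 2.00 log units lower from compound 1 to compound 2 (beyond the scatter)) and (a number 1.70 log units lower from compound 1 to compound 3 (beyond the scatter)), together with the small exchange of pyridin-4-yl for pyridin-2-yl (a number 0.30 log units higher from compound 2 to compound 3 (within the scatter)). Like those two groups, oxan-4-yl holds a hetero atom in its ring, but no measured compound shows a non-aromatic ring here. The expected change is therefore small (a number 0.10 log units higher from compound 3 to compound 4 (within the scatter)), not beyond the scatter. Compound 4 is estimated at 1.7 (expected range 1.2 to 2.2).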

Compound 4, distribution coefficient: 2.1
Estimate against measurement, compound 4: 0.40 log units below, within the range that was stated.
By their numbers in this assay, from the lowest: compounds 2 and 3 (each within the scatter of the next); then compound 4; then compound 1.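

In this assay, oxan-4-yl at this saturated ring carbon separates from both pyridines (a number 0.50 log units higher from compound 3 to compound 4 (beyond the scatter)) and (a number 0.80 log units higher from compound 2 to compound 4 (beyond the scatter)), although those two stayed within the scatter of each other. It still stays well under phenyl (a number 1.20 log units lower from compound 1 to compound 4 (beyond the scatter)), so a hetero atom in the ring does not by itself set the number at this position. Nothing offered here explains these steps. Because nitrogen gives way to oxygen as the ring stops being aromatic, the two changes cannot be told apart. Cyclohexyl, with no hetero atom, or piperidin-4-yl, an amine, could place the series differently.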